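This account rests on a few compounds, and the source may have more. Where it says the series, first, only, none or still open, it means among the compounds named here.

In a functional assay on HCT-116 cells (Homo sapiens) for inhibition, read by CCK-8 assay, with a stated time of 48 h (on this read-out lower numbers stand for stronger inhibition and higher numbers for weaker inhibition), compound 3 `COc1cc(N(Cc2ccc(Br)cc2)C(=O)CSC(=S)N2CCN(C(=O)OC(C)(C)C)CC2)cc(OC)c1OC` gives 11400 nM and compound 1 `COc1ccc(CN(C(=O)CN2CCN(C(=O)OC(C)(C)C)CC2)c2cc(OC)c(OC)c(OC)c2)cc1` gives 18100 nM, two numbers within the scatter of each other. Compound 2 `COc1ccc(CN(C(=O)CSC(=S)N2CCN(C(=O)OC(C)(C)C)CC2)c2ccc(Br)cc2)cc1` reads > 20000 nM, which is a limit of the assay and not a number. Compound 4 `COc1ccc(CN(C(=O)CSC(=S)N2CCN(C(=O)OC(C)(C)C)CC2)c2cc(OC)c(OC)c(OC)c2)cc1N` carries 3-amino-4-methoxyphenyl in place of 4-bromophenyl on a saturated chain carbon bound to an amide-type nitrogen. Going by the values given here, no measured pair differs in one place, so the size of this change is poorly constrained, and the reference point is compound 3 at 11400 nM. The expected step is a 3.8-fold lower number from compound 3 to compound 4 (0.58 log units; beyond the scatter), in the direction of stronger inhibition, with a wide margin. For compound 4 the estimated value is 3000 nM, with an expected range of 150 nM to 20000 nM.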

Compound 4, half-maximal inhibitory concentration: 352 nM
Beside the measured number, compound 4's estimate is 8.5-fold (0.93 log units) above it; measured number inside the range.
By their numbers in this assay, from the lowest: compound 4; then compounds 3 and 1 (each within the scatter of the next). At a limit, above all of these: compound 2.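

In this assay, 3-amino-4-methoxyphenyl in place of 4-bromophenyl on a saturated chain carbon bound to an amide-type nitrogen comes with a 32-fold lower number from compound 3 to compound 4 (1.51 log units; beyond the scatter). Going by these compounds alone, this is the first pair that differs in one place, and it shows that this position can move the read-out by a large step. No measurement shown gives a cause for this step. As far as these compounds go, the amine and the methoxy enter together, so their separate shares remain open. From the compounds shown here alone, whether a 3-aminobenzyl group alone or a 3-hydroxy-4-methoxybenzyl group would keep the step also remains open.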